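Halobenzyl sulfanyl series: chloro to fluoro swap

A few compounds are considered here, and "the series" means these few. Any claim that something is new, unique, unknown or untested is made for them only; others in the source may bear on it.

Measured so far:
compound 1 `COc1ccc(C2N=C(SCc3ccccc3Cl)NC(C)=C2C(=O)Nc2ccc(Br)cc2)cc1`: 11.3%
compound 2 `COc1ccc(C2N=C(SCc3ccc(Cl)cc3)NC(C)=C2C(=O)Nc2ccc(Br)cc2)cc1`: 22.7%

In a functional assay on the whole organism (artery, strain albino) with Rattus norvegicus as the target, with a stated time of 180 min, at a dose of 10 mg/kg by the oral route (a higher number here means more inhibition at the dose given (going by the name of the read-out), a lower number less inhibition), compound 2 gives 22.7% and stands highest of the two numbers; its nearest neighbour is compound 1, with a difference a number 11.4 percentage points higher from compound 1 to compound 2 (beyond the scatter). Compound 3 `COc1ccc(C2N=C(SCc3ccc(F)cc3)NC(C)=C2C(=O)Nc2ccc(Br)cc2)cc1` differs from compound 2 by fluoro in place of chloro on an aromatic carbon. Among the measured compounds shown here, no measured step swaps one halogen for another; the only known step moves a chloro between positions and does not bear on the halogen itself. A step of no size beyond the scatter is therefore expected, a number 2.7 percentage points lower from compound 2 to compound 3 (within the scatter), and compound 3 is estimated at 20%, within 8% to 32%.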

Compound 3, a percentage reported as inhibition, in the whole organism at one dose (the size of the read-out at that dose, not a potency): 17%
Compound 3: middle estimate off by 3 percentage points, on the high side; measured number inside the range.
By their numbers in this assay, from the lowest: compounds 1, 3 and 2 (each within the scatter of the next, the first and the last beyond it).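

Fluoro in place of chloro on this aromatic carbon, para to a large group, is the first halogen exchange in the series, and in this assay it reads as a number 5.7 percentage points lower from compound 2 to compound 3 (within the scatter) at this dose. Against the 2-chlorophenyl the 4-fluorophenyl gives a number 5.7 percentage points higher from compound 1 to compound 3 (within the scatter) in the same assay. Compound 3 therefore cannot be told apart from compound 1 or compound 2, although those two are separated by a number 11.4 percentage points higher from compound 1 to compound 2 (beyond the scatter) and so stand apart. Open, going by these compounds, is whether an amine or a carboxylic acid on this aromatic carbon would move the number beyond the scatter. Nothing measured here bears on why these numbers fall as they do.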